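Swapping the amide substituent in a weak antiproliferative series

This account rests on a few compounds, and the source may have more. Where it says the series, first, only, none or still open, it means among the compounds named here.

Compound 1 `CN1CCC(NC(=O)c2ccc(Cn3nc(-c4cnn(C)c4)c4ccccc4c3=O)cc2)CC1` is one of two measured compounds in a functional assay on HCT-116 cells (Homo sapiens) for antiproliferative activity, read by MTT assay, with a stated time of 72 h; a higher number here means a weaker inhibitor, a lower number a stronger inhibitor. Compound 1 gives 69500 nM, the only numeric result in this assay. Compound 2 `Cc1noc(C)c1-c1nn(Cc2ccc(C(=O)N3CCCCC3)cc2)c(=O)c2ccccc12` reaches only a limit of this assay, > 100000 nM, and the limit of > 100000 nM in this assay, at which 1 of the 2 values shown sits, notes that one of the two values shown sits at that limit. Compound 3 `Cn1cc(-c2nn(Cc3ccc(C(=O)NC4CC(C)(C)N([O])C(C)(C)C4)cc3)c(=O)c3ccccc23)cn1` has not yet been measured. It differs from compound 1 at one place: a group of 11 heavy atoms (9 carbon, 1 nitrogen, 1 oxygen; one six-membered non-aromatic ring with 1 hetero atom) in place of a group of 7 heavy atoms (6 carbon, 1 nitrogen; one six-membered non-aromatic ring with 1 hetero atom), on an amide-type nitrogen. Among the measured compounds shown here, no measured step of this kind is available, so the expected step of a 1.2-fold higher number from compound 1 to compound 3 (0.06 log units; within the scatter) is no change beyond the usual scatter. Compound 3 is therefore estimated at 80000 nM, within a range from 25000 nM to 250000 nM, with a real chance that this assay reports only a limit.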

Compound 3, half-maximal inhibitory concentration: 50500 nM
Beside the measured number, compound 3's estimate is 1.6-fold (0.20 log units) above it; the measured number falls inside the stated range.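

In this assay, replacing 1-methylpiperidin-4-yl on the amide-type nitrogen with the larger group gives a 1.4-fold lower number from compound 1 to compound 3 (0.14 log units; within the scatter), so this position accepts a group of 11 heavy atoms in place of one of 7 without a change beyond the scatter. The two groups share a six-membered non-aromatic ring with 1 hetero atom and the same counts of hydrogen-bond donors and acceptors, so the added atoms, including the oxygen, leave the number where it was. Nothing measured here explains this lack of change.

Still open, as far as these compounds go, is whether a plain 2,2,6,6-tetramethylpiperidin-4-yl group, without the oxygen, would behave the same way. Also open, from the compounds shown here alone, is whether a different kind of substituent on this nitrogen, such as a chain ending in a carboxylic acid or a primary amine, would move the number beyond the scatter.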